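Adding a methoxy group to compound 2

This account rests on a few compounds, and the source may have more. Where it says the series, first, only, none or still open, it means among the compounds named here.

Compound 1 `COc1cccc(/C=C2\CCC/C(=C\c3ccc(OC)c(OC)c3)C2=O)c1`: 4600 nM
Compound 2 `COc1ccc(/C=C2\CCC/C(=C\c3ccc(OC)c(OC)c3)C2=O)cc1`: 7800 nM

In a functional assay on MCF7 cells (Homo sapiens) for cytotoxicity, read by MTT assay, with a stated time of 72 h (on this read-out higher numbers stand for weaker inhibition and lower numbers for stronger inhibition), compound 2 stands at 7800 nM and compound 1 at 4600 nM in this small set, so the two lie within the scatter of each other. The next compound to be tested is compound 3 `COc1ccc(/C=C2\CCC/C(=C\c3ccc(OC)c(OC)c3)C2=O)cc1OC`. The change from compound 2 is methoxy in place of hydrogen on an aromatic carbon and it puts methoxy in place of hydrogen on an aromatic carbon, ortho to a methoxy group and meta to a large group. Compound 3 thus carries on that ring the methoxy groups of both measured compounds.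

For the measured compounds named here, the only measured step touching this ring is a 1.7-fold higher number from compound 1 to compound 2 (0.23 log units; within the scatter) and it stays small. That step relocates a methoxy group and adds none, so it bears on the change only indirectly. Going by the values given here, no measured pair shows the addition itself. In this assay no step beyond the scatter is therefore expected. The expected change is a 1.4-fold lower number from compound 2 to compound 3 (0.15 log units; within the scatter) and it remains an estimate. For compound 3 the estimated value is 5500 nM with an expected range from 2500 nM to 12000 nM as its limits.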

Compound 3, half-maximal inhibitory concentration: 13500 nM
For compound 3 the middle estimate is 2.5-fold (0.39 log units) below the measured one; measured number outside the range, above it.
By their numbers in this assay, from the lowest: compounds 1, 2 and 3 (each within the scatter of the next, the first and the last beyond it).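

In this assay, the methoxy group that enters ortho to a methoxy group and meta to a large group gives a 1.7-fold higher number from compound 2 to compound 3 (0.24 log units; within the scatter), so this addition to compound 2 does not separate the two compounds, and the extra heavy atoms at this place leave the read-out within the usual scatter. The same ring seen from the other side behaves differently: compound 3 also counts as a methoxy-for-hydrogen change on compound 1, and that change gives a 2.9-fold higher number from compound 1 to compound 3 (0.47 log units; beyond the scatter), a modest step and the only one in this set that lies beyond the scatter, so the effect of filling a ring position with methoxy depends on which methoxy group is already there. Nothing available explains why the two additions read differently, and the size of the step is all that can be stated.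

The compounds shown leave open whether a hydroxy group, a fluorine atom or an amine at this aromatic carbon would read like the methoxy group of compound 3. They also leave open whether a longer chain on that oxygen, such as ethoxy, would move the number further from that of compound 1.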